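Pyrazine hydrazones: bromo to methoxy on the benzylidene ring

The source may report more compounds than this note shows. Statements on the series, on what has been measured and on what is new or still open speak of the compounds shown alone.

Measured compounds:
compound 1, `O=C(N/N=C/c1ccccc1)c1cnccn1`, 100%
compound 2, `O=C(N/N=C/c1ccccc1Br)c1cnccn1`, 98%

In an ADME assay on J774 cells (Mus musculus) for cytotoxicity, read by MTT assay, with a stated time of 48 h, tested at 50 ug/mL (on this read-out lower numbers stand for a stronger effect and higher numbers for a weaker effect at the one concentration tested), compound 1 gives 100% and compound 2 gives 98%, so compound 2 stands with compound 1 within the scatter of this kind of measurement, the step being a number 2 percentage points lower from compound 1 to compound 2 (within the scatter). Compound 3, `COc1ccccc1/C=N/NC(=O)c1cnccn1`, differs from compound 2 by methoxy in place of bromo on an aromatic carbon. Among the measured compounds shown here, no measured step replaces bromo with methoxy; the only step known, a number 2 percentage points lower from compound 1 to compound 2 (within the scatter), concerns the bromo group itself and stayed within the scatter. Compound 3 is therefore expected to show no step beyond the scatter in this assay, namely no change at the digits printed from compound 2 to compound 3 (within the scatter). Compound 3 is estimated at 98%, in the range 87% to 106%.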

Compound 3, a percentage reported as activity, at one concentration (the size of the read-out at that concentration, not a potency): 97%
Compound 3: the middle estimate sits 1 percentage points above what was measured, within the range that was stated.
By their numbers in this assay, from the lowest: compounds 3, 2 and 1 (each within the scatter of the next).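

Methoxy in place of bromo on this aromatic carbon gives a number 1 percentage points lower from compound 2 to compound 3 (within the scatter), and methoxy in place of hydrogen gives a number 3 percentage points lower from compound 1 to compound 3 (within the scatter). A second group at this place, one that brings two heavy atoms and a hydrogen-bond acceptor, therefore also stays within the scatter of compound 1 in this assay. No evidence bears on why this should be so.

From the compounds shown here alone, whether an amine or a carboxylic acid on this aromatic carbon would also stay within the scatter remains open. So does whether methoxy on another carbon of this ring would behave as it does here.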